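A few compounds are considered here, and "the series" means these few. Any claim that something is new, unique, unknown or untested is made for them only; others in the source may bear on it.

Compound 1 `O=C(Cn1ccnc1)N1CCC(NS(=O)(=O)c2cc(S(=O)(=O)c3ccccc3)ccc2C(F)(F)F)CC1` and compound 2 `CCNC(=O)N1CCC[C@H]1C(=O)N1CCC(NS(=O)(=O)c2cc(S(=O)(=O)c3ccccc3)ccc2C(F)(F)F)CC1` differ only in the group on a carbonyl carbon. In a physicochemical assay for solubility (on this read-out higher numbers stand for higher solubility and lower numbers for lower solubility), compound 1 gives 100000 nM, and compound 2 gives 100000 nM, level with it. Compound 3 `CN1CCC[C@H]1C(=O)N1CCC(NS(=O)(=O)c2cc(S(=O)(=O)c3ccccc3)ccc2C(F)(F)F)CC1` differs from compound 2 at one place: methyl in place of ethylcarbamoyl on an amine nitrogen in a ring. For the measured compounds named here, only one measured step bears on this, no change at the digits printed from compound 1 to compound 2 (within the scatter), and it is a different swap, so the evidence is thin. It still gives no reason to expect a move beyond the scatter in this assay. The estimated step is no change at the digits printed from compound 2 to compound 3 (within the scatter). Compound 3 is expected at 100000 nM, with an estimated range of 50000 nM to 130000 nM.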

Compound 3, solubility: 100000 nM
For compound 3 middle estimate and measured number coincide at the digits printed, within the range that was stated.
By their numbers in this assay, from the lowest: compounds 1, 2 and 3 (each within the scatter of the next).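

In this assay, the step is no change at the digits printed from compound 2 to compound 3 (within the scatter) when methyl takes the place of ethylcarbamoyl on the amine nitrogen in the ring, so this position has now been read with two different groups and they print the same value. For the compounds shown here, the comparison with the first compound gives no change at the digits printed from compound 1 to compound 3 (within the scatter) when 1-methylpyrrolidin-2-yl takes the place of (1H-imidazol-1-yl)methyl on the carbonyl carbon. Nothing available explains why these swaps leave the read-out level. Still open, from the compounds shown here alone, is how a carboxylic acid or a longer chain on that ring nitrogen would read in this assay.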